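Pentylamino in place of pentyl on a carbonyl carbon

The source may report more compounds than this note shows. Statements on the series, on what has been measured and on what is new or still open speak of the compounds shown alone.

Of the compounds shown here, three sharing one core have been tested in a functional assay on M21 cells (Homo sapiens) for antiproliferative activity, read by sulforhodamine B assay, with a stated time of 48 h; a lower number here means a stronger inhibitor, a higher number a weaker inhibitor. Compound 1 `CC(C)c1ccccc1OS(=O)(=O)c1cccc(NC(=O)CCl)c1` gives 3900 nM. Compound 2 `CCCCCC(=O)Nc1ccc(S(=O)(=O)Oc2ccccc2C(C)C)cc1` gives 6700 nM. Compound 3 `CCCCCC(=O)Nc1ccc(S(=O)(=O)Oc2ccccc2I)cc1` gives 11000 nM, the highest of the three numbers, although the step of a 1.6-fold higher number from compound 2 to compound 3 (0.22 log units; within the scatter) lies within the scatter, so no order can be read there, while the gap to compound 1 lies beyond the scatter.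

Compound 4 `CCCCCNC(=O)Nc1ccc(S(=O)(=O)Oc2ccccc2I)cc1` has not yet been measured. It differs from compound 3 in one place: pentylamino in place of pentyl on a carbonyl carbon. Within the data shown here, the only measured step, a 1.6-fold higher number from compound 2 to compound 3 (0.22 log units; within the scatter), concerns a different change, iodo in place of isopropyl on an aromatic carbon, and stayed within the scatter. Among the measured compounds shown here, no measured step shows what pentylamino in place of pentyl on a carbonyl carbon does, so no shift beyond the scatter is expected in either direction. From compound 3, the expected step to compound 4 is no change at the digits printed from compound 3 to compound 4 (within the scatter). In this assay compound 4 is therefore estimated at 11000 nM, with a range from 4000 nM to 30000 nM to allow for the untested change.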

Compound 4, half-maximal inhibitory concentration: 5900 nM
Estimate against measurement, compound 4: 1.9-fold (0.27 log units) above; the range from low to high includes it.
By their numbers in this assay, from the lowest: compounds 1, 4, 2 and 3 (each within the scatter of the next, the first and the last beyond it).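

In this assay, among these compounds, this is the first view of what happens at the carbonyl carbon itself: swapping pentyl for pentylamino keeps the five-carbon chain but adds one nitrogen and one hydrogen-bond donor, and the result is a 1.9-fold lower number from compound 3 to compound 4 (0.27 log units; within the scatter). The position therefore accepts this change with no shift that can be told apart from the variation between repeated measurements, so neither a gain nor a loss can be claimed for it. Nothing available here explains the result or shows how this change acts in the cells.

The compounds shown leave open whether a longer chain such as heptyl, or a chain ending in an amine or a carboxylic acid, would move the number beyond the scatter at this carbonyl carbon. They also leave open whether pentylamino would behave the same with isopropyl in place of iodo.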